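Cytotoxicity notes: hydrazide series, step to a diol carbamoyl

The source may report more compounds than this note shows. Statements on the series, on what has been measured and on what is new or still open speak of the compounds shown alone.

Measured so far in an ADME assay on L6 cells (Rattus norvegicus) for cytotoxicity, read by resazurin assay, with a stated time of 70 h; on this read-out lower numbers stand for stronger inhibition and higher numbers for weaker inhibition:
- compound 1 `COc1cc(NC(C)CCCNC(=O)/C=C/c2cccc(C(F)(F)F)c2)c2ncccc2c1`: 16200 nM
- compound 2 `COc1cc(NC(C)CCCNC(=O)NNC(=O)/C(C)=C/c2ccccc2)c2ncccc2c1`: 36500 nM
- compound 3 `COc1cc(NC(C)CCCNC(=O)NNC(=O)/C=C/c2cc(C(F)(F)F)cc(C(F)(F)F)c2)c2ncccc2c1`: its result is a limit of the assay, > 170000 nM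

Compound 2 holds the higher of the two numbers reported; compound 1 sits at a lower number, a gap beyond the usual scatter. The entry for compound 3 is a limit only, as noted by the limit of > 170000 nM in this assay, at which 1 of the 3 values shown sits, so its place relative to compound 2 is not fixed by a number.

Compound 4 `COc1cc(NC(C)CCCNC(=O)NNC(=O)N(CCO)CCO)c2ncccc2c1` is not yet measured. It differs from compound 2 in one place: bis(2-hydroxyethyl)amino in place of 1-methyl-2-phenylethenyl on a carbonyl carbon. Among the compounds with values here, no measured pair in this set shows this exact change, so the direction rests on expectation alone. The working expectation for compound 4 is a move toward a higher number in this assay, with a real chance that only a limit is returned.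

The step expected from compound 2 to compound 4 is a 2.5-fold higher number from compound 2 to compound 4 (0.39 log units; beyond the scatter), toward weaker inhibition. Compound 4 is estimated at 90000 nM, with a range from 30000 nM to 200000 nM.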

Compound 4, half-maximal inhibitory concentration: 178000 nM
Beside the measured number, compound 4's estimate is 2.0-fold (0.30 log units) below it, and the stated range covers the measured number.
By their numbers in this assay, from the lowest: compound 1; then compound 2; then compound 4.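

In this assay, bis(2-hydroxyethyl)amino in place of 1-methyl-2-phenylethenyl on a carbonyl carbon gives a 4.9-fold higher number from compound 2 to compound 4 (0.69 log units; beyond the scatter). Within the data shown here, this is the first one-place step in the set, and it shows that a group with no ring and no double bond outside a ring, carrying hydroxyl groups instead, moves the number toward weaker inhibition at this position. Compound 3 returns only a limit, and the number for compound 4 has to be read close to that ceiling: the limit of > 170000 nM in this assay, at which 1 of the 4 values shown sits.

A single step cannot separate the departure of the phenyl ring from the arrival of the two hydroxyethyl arms. As far as these compounds go, whether a plain diethylamino group, without the hydroxyl groups, on the same carbonyl carbon would shift the number in the same direction stays open.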